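From an Ester to a Fluorinated Sulfoxide on the Shared Core

The compounds below may be only part of what the source reports. "The series", "measured", "known", "first", "only" and "open" are said of these compounds alone.

Compound 1 `CCOC(=O)c1sc2nc(-c3cccs3)cc(-c3ccccc3)c2c1N` carries an ethoxycarbonyl group on its core. In an assay for inhibition of 15-hydroxyprostaglandin dehydrogenase [NAD(+)] (Homo sapiens), read by fluorescence, with a stated time of 15 min, in the presence of a further agent that is not named here (on this read-out higher numbers stand for weaker inhibition and lower numbers for stronger inhibition), compound 1 gives > 7500 nM, which is a limit of the assay rather than a measured number. Among the three values shown, compound 1 is the only one to sit at the limit of > 7500 nM in this assay, at which 1 of the 3 values shown sits. Compound 2 `CCCC[S+]([O-])c1sc2nc(-c3nccs3)cc(-c3ccc(CNC(C)=O)cc3)c2c1N` gives 2.5 nM in this assay. Compound 3 `CCCC[S+]([O-])c1sc2nc(-c3nccs3)cc(-c3cnc(C)[nH]3)c2c1N` gives 2.3 nM. Both of these are built on the same core as compound 1 but differ from it in several places at once, so their values show only that strong inhibition is reachable on this core, not which change brings it.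

Compound 4 `Nc1c([S+]([O-])CCCF)sc2nc(-c3cccs3)cc(-c3ccccc3)c12` has not yet been measured in this assay. It differs from compound 1 in one place: a group of 6 heavy atoms (3 carbon, 1 oxygen, 1 fluorine, 1 sulfur; no ring) in place of a group of 5 heavy atoms (3 carbon, 2 oxygen; no ring), on an aromatic carbon. Among the measured compounds shown here, with no measured step of this kind to lean on, the expected size of the change is uncertain, but the estimate for compound 4 in this assay is 150 nM, with a range from 10 nM to 3000 nM. This estimate would mean a step from compound 1 to compound 4 of an at least 50-fold lower number from compound 1 to compound 4 (1.69 log units; beyond the scatter), in the direction of stronger inhibition.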

Compound 4, half-maximal inhibitory concentration: 6.1 nM
For compound 4 the middle estimate is 25-fold (1.39 log units) above the measured one; the whole stated range lies above it.
By their numbers in this assay, from the lowest: compounds 3 and 2 (each within the scatter of the next); then compound 4. At a limit, above all of these: compound 1.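

Replacing the ethoxycarbonyl group with the fluorinated sulfoxide chain, on the aromatic carbon next to the ring sulfur, gives an at least 1200-fold lower number from compound 1 to compound 4 (3.08 log units; beyond the scatter) in this assay. Compounds 2 and 3 differ from compound 1 in several places at once, whereas this single change on the otherwise unchanged core of compound 1 is enough to reach strong inhibition. Compound 1 gives only a limit of the assay, so the step has a minimum size and no exact one: the limit of > 7500 nM in this assay, at which 1 of the 4 values shown sits.

The step replaces the whole group at once, so it does not separate the part played by the sulfoxide from that of the fluorine or the chain. From the compounds shown here alone, it also remains open how a plain propyl sulfoxide, a sulfone or a carboxylic acid would read at this same place on this core.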